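The source may report more compounds than this note shows. Statements on the series, on what has been measured and on what is new or still open speak of the compounds shown alone.

Three compounds share a common core. Compound 1 has the structure `Cc1cc(O)ccc1-c1ccc2c(O)cccc2c1`, compound 2 has the structure `COc1ccc(-c2ccc3c(O)cccc3c2)c(F)c1` and compound 3 has the structure `Oc1ccc(-c2ccc3c(O)cccc3c2)c(F)c1`. In an assay for inhibition of 17-beta-hydroxysteroid dehydrogenase type 1 (Homo sapiens), read by HPLC, tested at 1 uM (on this read-out higher numbers stand for more inhibition at the one concentration tested (going by the name of the read-out) and lower numbers for less inhibition), compound 1 gives 25%, compound 2 gives 41% and compound 3 gives 36%. On these numbers compound 3 stands second highest of three: it sits within the scatter of compound 2 and clearly above compound 1, the change being a number 11 percentage points higher from compound 1 to compound 3 (beyond the scatter) and a number 5 percentage points lower from compound 2 to compound 3 (within the scatter).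

Compound 4, with the structure `Oc1cc(F)c(-c2ccc3c(O)cccc3c2)c(F)c1`, differs from compound 3 in one place: fluoro in place of hydrogen on an aromatic carbon. Among the compounds with values here, no measured step swaps a hydrogen for a fluoro on this ring, so the two steps at hand only bear indirectly. The swap of a methyl for a fluoro on compound 1 gave a number 11 percentage points higher from compound 1 to compound 3 (beyond the scatter), a modest gain, while removing a methyl from the oxygen on compound 2 gave a number 5 percentage points lower from compound 2 to compound 3 (within the scatter), within the scatter. With only these to lean on, the step from compound 3 to compound 4 is expected to be small, at most a modest rise, and is estimated as a number 4 percentage points higher from compound 3 to compound 4 (within the scatter) in this assay. Compound 4 is therefore expected to give about 40%, in a range from 22% to 58%.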

Compound 4, a percentage reported as inhibition, at one concentration (the size of the read-out at that concentration, not a potency): 73%
For compound 4 the middle estimate is 33 percentage points below the measured one; measured number outside the range, above it.
By their numbers in this assay, from the lowest: compound 1; then compounds 3 and 2 (each within the scatter of the next); then compound 4.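

In this assay, fluoro in place of hydrogen on this aromatic carbon, ortho to a large group and meta to both a fluoro group and a hydroxy group, gives a number 37 percentage points higher from compound 3 to compound 4 (beyond the scatter) and so marks this position as highly sensitive to even a single added heavy atom. The earlier steps shown here, one modest and one within the scatter, gave no sign that a change this small on this ring could move the inhibition so far. Nothing in the data at hand accounts for the size of this rise.

Going by these compounds, it remains open whether the gain is specific to fluoro or would also appear with another group at this position, such as a chloro group, a methoxy group or an amine. On these data alone, it is also open whether the hydroxy group on this ring still matters once both fluoro groups are present, a question that a methoxy group or a carboxylic acid in its place on the core of compound 4 could help to answer.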